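A few compounds are considered here, and "the series" means these few. Any claim that something is new, unique, unknown or untested is made for them only; others in the source may bear on it.

Working notes on the series in an assay on membranes from frontal cortex for displacement of a labelled ligand from Adrenergic receptor alpha-1 (Rattus norvegicus), read by scintillation counting, with a stated time of 45 min; a lower number here means a stronger inhibitor, a higher number a weaker inhibitor.

Compound 1 `CCC1(CCCCN2CCN(c3ccccc3OC)CC2)C(=O)Nc2ccccc21` gives 27 nM in this assay. Compound 2 `CCC1(CCCCN2CCN(c3ccc(Cl)cc3)CC2)C(=O)Nc2ccccc21` gives 93 nM. Compound 3 `CCC1(CCCCN2CCN(c3ccc(F)cc3)CC2)C(=O)Nc2ccccc21` gives 39 nM. Among these three numbers compound 3 holds the second highest place; its nearest neighbour is compound 1, with a 1.4-fold higher number from compound 1 to compound 3 (0.16 log units; within the scatter), and its furthest is compound 2, with a 2.4-fold lower number from compound 2 to compound 3 (0.38 log units; beyond the scatter). Among the compounds with values here, the only other recorded step, a 3.4-fold higher number from compound 1 to compound 2 (0.54 log units; beyond the scatter), sets the replacement of 2-methoxyphenyl by 4-chlorophenyl as a modest rise.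

Compound 4 `CCC1(CCCCN2CCN(c3ccc(Cl)c(Cl)c3)CC2)C(=O)Nc2ccccc21` differs from compound 3 in one place: 3,4-dichlorophenyl in place of 4-fluorophenyl on an amine nitrogen in a ring. Within the data shown here, no measured step covers a 3,4-dichlorophenyl on this core. Among the measured compounds shown here, the steps that bear on it are a 2.4-fold lower number from compound 2 to compound 3 (0.38 log units; beyond the scatter), read in reverse, and a 3.4-fold higher number from compound 1 to compound 2 (0.54 log units; beyond the scatter); both show that a chloro-bearing aryl on the ring nitrogen returns a higher number than the fluoro or methoxy partner, and both are modest in size. Adding a second chloro is not covered by any measured pair. A modest rise beyond the scatter is therefore expected for a 3.1-fold higher number from compound 3 to compound 4 (0.49 log units; beyond the scatter). Compound 4 is estimated at 120 nM, with a range from 45 nM to 320 nM.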

Compound 4, inhibition constant: 125 nM
Estimate against measurement, compound 4: 1.0-fold (0.02 log units) below; the range from low to high includes it.
By their numbers in this assay, from the lowest: compounds 1 and 3 (each within the scatter of the next); then compounds 2 and 4 (each within the scatter of the next).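

In this assay, within the data shown here, a chloro added to the 4-chlorophenyl of compound 2 gives no change that can be told from the scatter (a 1.3-fold higher number from compound 2 to compound 4 (0.13 log units; within the scatter)), a pair that the earlier compounds did not offer. The 3,4-dichlorophenyl nevertheless stands clearly apart from the 4-fluorophenyl (a 3.2-fold higher number from compound 3 to compound 4 (0.51 log units; beyond the scatter)) and from the 2-methoxyphenyl (a 4.6-fold higher number from compound 1 to compound 4 (0.67 log units; beyond the scatter)), so at this place on the ring nitrogen the four compounds fall into two groups: the chloro-bearing aryls of compounds 2 and 4 with the higher numbers, and the aryls of compounds 1 and 3 with the lower, with no compound shown going against this. Nothing available accounts for this grouping.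

The compounds shown leave open where an unsubstituted phenyl would fall, and so whether the chloro or the fluoro is what separates these aryls from a plain ring. They also leave open whether a trifluoromethyl, a hydroxyl or a pyridine ring in place of the phenyl would stay with the lower pair or join the higher one.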